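Ethyl for chloro on the pendant phenyl ring

The source may report more compounds than this note shows. Statements on the series, on what has been measured and on what is new or still open speak of the compounds shown alone.

The measured compounds, each with its result in an assay on cells with Cystic fibrosis transmembrane conductance regulator variant F508del (Homo sapiens) as the target, read by voltage clamp, with a stated time of 24 h, in the presence of a further agent that is not named here; a lower number here means that less compound is needed, a higher number that more compound is needed for the effect:
compound 1, `COc1ncc(C(F)(F)F)cc1CO[C@H]1[C@H](C(C)(C)C)[C@@H](C(=O)O)N(C(=O)[C@@H]2CCCCO2)[C@H]1c1ccccc1C(C)C`, gives 35 nM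
compound 2, `COc1ncc(C(F)(F)F)cc1CO[C@H]1[C@H](C(C)(C)C)[C@@H](C(=O)O)N(C(=O)[C@@H]2CCCCO2)[C@H]1c1ccccc1C1CC1`, gives 66 nM
compound 3, `COc1ncc(C(F)(F)F)cc1CO[C@H]1[C@H](C(C)(C)C)[C@@H](C(=O)O)N(C(=O)[C@@H]2CCCCO2)[C@H]1c1ccccc1Cl`, gives 222 nM

Compound 3 has the highest number of the three in this assay: its nearest neighbour is compound 2, at a 3.4-fold higher number from compound 2 to compound 3 (0.53 log units; beyond the scatter), and the wider gap is a 6.3-fold higher number from compound 1 to compound 3 (0.80 log units; beyond the scatter). Both of those steps lie beyond the scatter, so compound 3 needs noticeably more compound than either of the others.

Compound 4, `CCc1ccccc1[C@H]1[C@@H](OCc2cc(C(F)(F)F)cnc2OC)[C@H](C(C)(C)C)[C@@H](C(=O)O)N1C(=O)[C@@H]1CCCCO1`, differs from compound 3 in one spot: ethyl in place of chloro on an aromatic carbon. The measured steps that bear on this are those that replace the chloro with a carbon group of similar size. Going the other way, compound 1 carries isopropyl, compound 2 carries cyclopropyl, and the step between them, a 1.9-fold higher number from compound 1 to compound 2 (0.28 log units; within the scatter), stays within the scatter, while both stand well below compound 3. Ethyl is another small carbon chain at the same place, so a step downward from compound 3, of a size close to those seen, is expected. The estimated step is a 3.7-fold lower number from compound 3 to compound 4 (0.57 log units; beyond the scatter). Compound 4 is therefore expected to give about 60 nM in this assay, most likely between 30 nM and 130 nM.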

Compound 4, half-maximal effective concentration: 48 nM
Estimate against measurement, compound 4: 1.3-fold (0.10 log units) above; the measured number falls inside the stated range.
By their numbers in this assay, from the lowest: compounds 1, 4 and 2 (each within the scatter of the next); then compound 3.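

In this assay, replacing chloro with ethyl on this aromatic carbon, ortho to a large group, gives a 4.6-fold lower number from compound 3 to compound 4 (0.67 log units; beyond the scatter) and places a third carbon group well away from chloro. Ethyl cannot be separated from the two earlier carbon groups: the change from cyclopropyl gives a 1.4-fold lower number from compound 2 to compound 4 (0.14 log units; within the scatter), and trimming isopropyl to ethyl, with hydrogen in place of methyl, gives a 1.4-fold higher number from compound 1 to compound 4 (0.14 log units; within the scatter). Among these compounds, then, the position accepts ethyl, isopropyl and cyclopropyl with no readable difference, so neither the extra methyl of isopropyl nor the ring of cyclopropyl changes the number beyond the usual scatter, and only compound 3, the chloro compound, stands apart.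

Nothing here gives a measured reason for the gap between chloro and the carbon groups. The compounds shown also leave open how far this tolerance extends, since a methyl at this place, a longer chain such as butyl, or an oxygen-linked group such as methoxy could either fall in with the carbon groups or move towards chloro.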